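Removing the acetyl group from compound 2

The compounds below may be only part of what the source reports. "The series", "measured", "known", "first", "only" and "open" are said of these compounds alone.

Measured so far:
compound 1 `COc1ccc(/C=C/C(=O)OC[C@H]2O[C@@H](O[C@H]3OC=C[C@@]4(O)[C@@H]3[C@](C)(O)C[C@@H]4O)[C@H](O[C@@H]3O[C@H](CO)[C@@H](O)[C@H](O)[C@H]3O)[C@@H](O)[C@@H]2O)cc1` — 39000 nM
compound 2 `CC(=O)O[C@]1(C)C[C@H](O)[C@H]2C=CO[C@H](O[C@@H]3O[C@H](CO)[C@@H](O)[C@H](O)[C@H]3O)[C@H]21` — 44200 nM

In a functional assay for inhibition, with a stated time of 60 min (a higher number here means a weaker inhibitor, a lower number a stronger inhibitor), compound 1 gives 39000 nM, and compound 2 gives 44200 nM. Compound 2 has the highest of the two numbers, but its gap to compound 1 lies within the scatter, so the two cannot be told apart. Compound 3 `C[C@@]1(O)C[C@H](O)[C@H]2C=CO[C@H](O[C@@H]3O[C@H](CO)[C@@H](O)[C@H](O)[C@H]3O)[C@H]21` is the next compound. The change from compound 2 to compound 3 is hydrogen in place of acetyl on an oxygen on a saturated carbon. Nothing measured here shows what such a change does. Within the data shown here, with no comparable step available, the expected step of a 1.0-fold higher number from compound 2 to compound 3 (0.01 log units; within the scatter) is none beyond the scatter. Compound 3 is therefore expected to give about 45000 nM, in the range 18000 nM to 110000 nM.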

Compound 3, half-maximal inhibitory concentration: 44100 nM
The estimate for compound 3 lay 1.0-fold (0.01 log units) above the measured number, within the range that was stated.
By their numbers in this assay, from the lowest: compounds 1, 3 and 2 (each within the scatter of the next).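

In this assay, among these compounds, going from acetoxy to hydroxy on this oxygen comes with a 1.0-fold lower number from compound 2 to compound 3 (0.00 log units; within the scatter) and gives the first direct reading of this change. At this position, the acetyl group can be lost with no difference that this assay can detect. Nothing available explains this result.

Still open, from the compounds shown here alone, is whether a different group on this oxygen, such as a methyl ether or a longer benzoyl ester, would shift the number. Also open, going by these compounds, is whether an amine in place of this hydroxy would do so.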